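Working notes: one more hydroxy on compound 1

A few compounds are considered here, and "the series" means these few. Any claim that something is new, unique, unknown or untested is made for them only; others in the source may bear on it.

Values in a functional assay on KB403 cells (Homo sapiens) for cytotoxicity, read by MTT assay, with stated times of 6 h and 48 h; a higher number here means a weaker inhibitor, a lower number a stronger inhibitor
- compound 1 `Cn1c(/C=C/C(=O)c2ccccc2O)cc(Br)c1Br` gives 8320 nM
- compound 2 `Cn1c(/C=C/C(=O)c2ccc(O)cc2O)cc(Br)c1Br` gives 12000 nM
- compound 3 `Cn1c(/C=C/C(=O)c2cc(O)ccc2O)cc(Br)c1Br` is not yet measured

Among the compounds with values here, compound 1 and compound 2 are the only measured compounds, and they lie within the scatter of each other, so no order can be drawn between them. Compound 3 differs from compound 1 by hydroxy in place of hydrogen on an aromatic carbon, meta to a large group and para to a hydroxy group (hydroxy in place of hydrogen on an aromatic carbon). Within the data shown here, the one measured step of this kind, at a different carbon, is a 1.4-fold higher number from compound 1 to compound 2 (0.16 log units; within the scatter), which is thin evidence. On that single step, no change beyond the scatter is expected in this assay, in either direction. Compound 3 is expected at about 10000 nM, with an estimated range of 5000 nM to 20000 nM for repeat measurements. The estimate means an expected step of a 1.2-fold higher number from compound 1 to compound 3 (0.08 log units; within the scatter), which is no real change.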

Compound 3, half-maximal inhibitory concentration: >= 100000 nM
Compound 3 was reported as a limit (the forecaster's own chance of this, stated with the estimate: 10%); middle value at least 10-fold (1.00 log units) away from the limit.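

Hydroxy in place of hydrogen is not a neutral change on this ring: in this assay, the outcome depends on the carbon, with a 1.4-fold higher number from compound 1 to compound 2 (0.16 log units; within the scatter) at one carbon and an at least 12-fold higher number from compound 1 to compound 3 (1.07 log units; beyond the scatter) at the carbon meta to a large group and para to a hydroxy group. This position therefore carries a large change in the direction of weaker inhibition, which the earlier pair gave no sign of. Compound 3 gives >= 100000 nM, which is a limit of the assay and not a number: the limit of >= 100000 nM in this assay, at which 1 of the 3 values shown sits.

On these data alone, whether this step belongs to hydroxy alone, or would also come with methoxy, an amine or fluorine on the same carbon, stays open. The compounds shown give no reason for the step, and a single change at this position supports no wider rule for the series.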